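Inverting Two Stereocentres of Compound 2

The source may report more compounds than this note shows. Statements on the series, on what has been measured and on what is new or still open speak of the compounds shown alone.

In an ADME assay on liver for metabolic stability, with Liver microsome (Rattus norvegicus) as the target, read by LC-MS, using microsomes, with a stated time of 5 h (on this read-out higher numbers stand for fast clearance and lower numbers for slow clearance), compound 1 (`O[C@H](c1ccccn1)[C@]1(c2cc(C(F)(F)F)ccn2)C[C@H](O)C1`) gives 50 mL/min/kg and compound 2 (`C[C@]1(O)C[C@](c2cc(C(F)(F)F)ccn2)([C@@H](O)c2ccccn2)C1`) gives 100 mL/min/kg with the two numbers lying within the usual scatter of each other. Within the data shown here, compound 2 therefore cannot be separated from compound 1 on the only two numbers available. Compound 3 (`C[C@]1(O)C[C@](c2cc(C(F)(F)F)ccn2)([C@H](O)c2ccccn2)C1`) is still unmeasured, and its relation to compound 2 (the two compounds have the same atoms and bonds and differ only in configuration as drawn: 2 of 3 stereo elements differ; a stereocentre at a saturated ring carbon is drawn R in compound 2 and S in compound 3; a stereocentre at a saturated chain carbon is drawn R in compound 2 and S in compound 3) is one of configuration alone: the two compounds have the same atoms and bonds. Among the measured compounds shown here, no measured pair shows what a change of configuration alone does in this assay and the expectation can rest only on the two values in hand. The step expected in this assay is small, downward and not beyond the scatter, estimated as a 1.4-fold lower number from compound 2 to compound 3 (0.15 log units; within the scatter) with little firmer to guide it. Compound 3 is estimated at 70 mL/min/kg with 30 mL/min/kg to 140 mL/min/kg as the expected range.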

Compound 3, clearance: 100 mL/min/kg
For compound 3 the middle estimate is 1.4-fold (0.15 log units) below the measured one; measured number inside the range.
By their numbers in this assay, from the lowest: compounds 1, 2 and 3 (each within the scatter of the next).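

In this assay, the two inversions, at the saturated ring carbon and at the saturated chain carbon, give no change at the digits printed from compound 2 to compound 3 (within the scatter). Among these compounds, this is the first measured pair to isolate configuration, so a change of two stereocentres together has now been read directly at this position, and the read-out does not separate the two forms: the fact that compounds 2 and 3 differ only in the configuration as drawn. Methyl in place of hydrogen on a saturated ring carbon gives a 2.0-fold higher number from compound 1 to compound 3 (0.30 log units; within the scatter), so in this configuration the methyl is likewise not resolved from the scatter.

The compounds shown leave open what inverting either stereocentre alone would do, as the two change together here, so any opposing effects of the two inversions cannot be read. They also leave open how an amine or a longer chain in place of the methyl on the saturated ring carbon would read.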